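This account rests on a few compounds, and the source may have more. Where it says the series, first, only, none or still open, it means among the compounds named here.

Values in a functional assay for antagonist activity, with Cavia porcellus as the target; a lower number here means a stronger inhibitor, a higher number a weaker inhibitor:
- Compound 1 `CCN(CC)CC#CCCC1SCCCS1`: > 10000000 nM. This value is a limit.
- Compound 2 `CCN(CC)CC#CCCC1(C(c2ccccc2)c2ccccc2)SCCCS1`: 500 nM
- Compound 3 `CCN(CC)CC#CCCC1(Cc2ccccc2)SCCCS1`: 1960 nM

Among the exact numbers, compound 3 stands highest. The next step leads to compound 4 `CCN(CC)CC#CCCC1(c2ccccc2)SCCCS1`: phenyl in place of benzyl on a saturated ring carbon. Among the compounds with values here, two measured steps bear on it. Placing benzyl on that carbon gave the large at least 5100-fold lower number from compound 1 to compound 3 (3.70 log units; beyond the scatter). Removing a phenyl from the chain carbon gave the modest 3.9-fold higher number from compound 2 to compound 3 (0.59 log units; beyond the scatter). Compound 4 retains an aromatic ring at the ring carbon, so no large loss is expected in this assay, and no step beyond the scatter is expected in either direction. The expected change is a 1.2-fold lower number from compound 3 to compound 4 (0.06 log units; within the scatter). Compound 4 is estimated at 1700 nM, with an expected range of 450 nM to 6500 nM.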

Compound 4, antagonist equilibrium constant: 900 nM
Compound 4: the middle estimate sits 1.9-fold (0.28 log units) above what was measured; low and high end bracket the measured number.
By their numbers in this assay, from the lowest: compounds 2 and 4 (each within the scatter of the next); then compound 3. At a limit, above all of these: compound 1.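

In this assay, phenyl in place of benzyl on the saturated ring carbon gives a 2.2-fold lower number from compound 3 to compound 4 (0.34 log units; beyond the scatter), so the benzyl chain carbon is not needed at this position for a number in this range. Phenyl in place of hydrogen there gives an at least 11000-fold lower number from compound 1 to compound 4 (4.04 log units; beyond the scatter), which shows that an aromatic ring directly on that carbon is enough for the large gain. Compound 1 stands at a limit, so this step is only a bound: the limit of > 10000000 nM in this assay, at which 1 of the 4 values shown sits.

Open, going by these compounds, is whether an aromatic ring is required at all, since cyclohexyl on this carbon would test that. Also open, on these data alone, is how a methoxy or chloro group on the phenyl ring, or a pyridyl ring in its place, would move the number.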